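Returning to a six-membered ring on the amide

This account rests on a few compounds, and the source may have more. Where it says the series, first, only, none or still open, it means among the compounds named here.

Compound 2 `Cc1cc(S(=O)(=O)N2C=CNC(=O)[C@H]2CC(=O)N2CC[C@H](N3CCCC3)C2)c(C)cc1Cl` is the weaker of the two measured compounds: in an in vitro functional assay on cells for antagonist activity at B1 bradykinin receptor (Homo sapiens), read by luminescence and calcium flux, with a stated time of 2 h (on this read-out lower numbers stand for stronger inhibition and higher numbers for weaker inhibition), compound 2 gives 19 nM, while compound 1 `Cc1cc(S(=O)(=O)N2C=CNC(=O)[C@H]2CC(=O)N[C@H]2CCN(C)CC2(C)C)c(C)cc1Cl` gives 0.28 nM. Among the compounds with values here, the single measured step, a 68-fold higher number from compound 1 to compound 2 (1.83 log units; beyond the scatter), swapped a six-membered ring for two five-membered rings on the carbonyl carbon of the amide.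

Compound 3 `Cc1cc(S(=O)(=O)N2C=CNC(=O)[C@H]2CC(=O)N2CCC(N(C)C)CC2)c(C)cc1Cl` is not yet measured. Its change from compound 2 is a group of 9 heavy atoms (7 carbon, 2 nitrogen; one six-membered non-aromatic ring with 1 hetero atom) in place of a group of 10 heavy atoms (8 carbon, 2 nitrogen; 2 five-membered non-aromatic rings with 1 hetero atom each), on a carbonyl carbon, so the amide again carries a six-membered ring, as compound 1 does, though the ring in compound 3 is attached through its nitrogen rather than through a carbon bearing a hydrogen.

Within the data shown here, the only step that bears on this is the one from compound 1 to compound 2, which was large and ran toward weaker inhibition when the six-membered ring was replaced. Reversing part of that change is therefore expected to move compound 3 back toward stronger inhibition, though not fully to the level of compound 1. Compound 3 is estimated at 4 nM in this assay, a step of a 4.8-fold lower number from compound 2 to compound 3 (0.68 log units; beyond the scatter), with a likely range from 1 nM to 15 nM.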

Compound 3, half-maximal inhibitory concentration: 152 nM
Estimate against measurement, compound 3: 38-fold (1.58 log units) below; measured number outside the range, above it.
By their numbers in this assay, from the lowest: compound 1; then compound 2; then compound 3.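

In this assay, returning to a six-membered ring on the carbonyl carbon does not bring back the stronger inhibition: the 4-(dimethylamino)piperidin-1-yl group gives an 8.0-fold higher number from compound 2 to compound 3 (0.90 log units; beyond the scatter). Ring size alone therefore does not decide the number at this position, for the groups in compound 1 and compound 3 each hold one six-membered ring and 2 nitrogens, yet the step between them is a 540-fold higher number from compound 1 to compound 3 (2.73 log units; beyond the scatter), the largest of the three listed here. So the way the group is built and joined to the carbonyl matters more than its ring count, and nothing measured here explains why that is so.

The three groups differ in several features at once, including whether the amide hydrogen is present, so these compounds cannot show which feature accounts for the loss. A 4-(pyrrolidin-1-yl)piperidin-1-yl group, which keeps the amine of compound 2 on the ring of compound 3, would separate the effect of the ring from that of the amine.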